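The source may report more compounds than this note shows. Statements on the series, on what has been measured and on what is new or still open speak of the compounds shown alone.

Within the data shown here, in an ADME assay on SH-SY5Y cells (Homo sapiens) for cytotoxicity, read by MTT assay, with a stated time of 72 h (a higher number here means a weaker inhibitor, a lower number a stronger inhibitor), compound 1 (`O=C(CN1CCN(C(=O)c2ccc(F)cc2)CC1)N1CCN(CCCc2c[nH]c3ccccc23)CC1`) gives 188000 nM and compound 2 (`COc1ccc2[nH]cc(CCCN3CCN(C(=O)CN4CCN(C(=O)c5ccc(Cl)cc5)CC4)CC3)c2c1`) gives 159000 nM as the only numbers so far. These two values lie within the usual scatter of repeated measurements, so compound 2 stands level with compound 1 and the pair cannot be ranked. The next compound is compound 3 (`COc1ccc2[nH]cc(CCCN3CCN(C(=O)CN4CCN(C(=O)c5ccc(F)cc5)CC4)CC3)c2c1`), which has not yet been measured. It differs from compound 2 in a single place. The change (fluoro in place of chloro on an aromatic carbon) puts fluoro in place of chloro on an aromatic carbon, para to a large group, so that 4-chlorophenyl becomes 4-fluorophenyl. Among the measured compounds shown here, no two measured compounds differ in only one place, so the data give no direct reading of what this swap does. With compound 2 at 159000 nM as the starting point, the change expected in this assay is none beyond the scatter, in no set direction. The estimate amounts to a 1.1-fold higher number from compound 2 to compound 3 (0.03 log units; within the scatter) and that expected step stays within the scatter. Compound 3 is expected at 170000 nM with an estimated range from 90000 nM to 320000 nM once its measurement is made.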

Compound 3, half-maximal inhibitory concentration: > 200000 nM
Compound 3 ended at the assay's limit (the forecaster's own chance of this, stated with the estimate: 10%); at least 1.1-fold (0.07 log units) between middle value and limit.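

In this assay compound 3 gives > 200000 nM, which is a limit of the assay and not a number. Among these compounds, this gives the first direct reading of fluoro in place of chloro on an aromatic carbon, para to a large group: the swap gives an at least 1.2-fold higher number from compound 2 to compound 3 (0.09 log units; that floor lies within the scatter), so it can be said only that the real step is no smaller than this floor, and a floor this small does not establish a change. The same holds for methoxy in place of hydrogen on an aromatic carbon, which gives an at least 1.0-fold higher number from compound 1 to compound 3 (0.02 log units; that floor lies within the scatter), and the true size of both steps stays hidden at the top of the measurable range: the limit of > 200000 nM in this assay, at which 1 of the 3 values shown sits.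

The compounds shown leave open whether a bromo, a methyl or a nitrile at the same place on the aromatic ring would move the number beyond the scatter. From the compounds shown here alone, it also stays open whether a hydroxyl or an amine in place of the methoxy, or a longer chain leading to the shared core, would give a value that falls clearly inside the range of the assay.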